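A few compounds are considered here, and "the series" means these few. Any claim that something is new, unique, unknown or untested is made for them only; others in the source may bear on it.

Measured in a functional assay on WiDr cells (Homo sapiens) for antiproliferative activity, read by sulforhodamine B assay, with a stated time of 48 h; a lower number here means a stronger inhibitor of growth, a higher number a weaker inhibitor of growth:
- Compound 1 `CC(C)(C)[Si](C)(C)O[C@H]1CCCO[C@@H]1CO`: > 100000 nM
- Compound 2 `CC(C)(C)[Si](C)(C)O[C@@H]1CCCO[C@@H]1CO`: > 100000 nM
- Compound 3 `O=C(COC[C@H]1OCCC[C@@H]1O)OCc1ccccc1`: > 100000 nM

Each of these three entries is a limit and not a number. The same holds for compound 2, which therefore has no exact place on the scale, and the whole series rests on (the limit of > 100000 nM in this assay, at which 3 of the 3 values shown sit). Compound 4 `COC(=O)/C=C/OC[C@H]1OCCC[C@H]1O[Si](C)(C)C(C)(C)C` has 2-(methoxycarbonyl)ethenyl in place of hydrogen on an oxygen on a saturated carbon of compound 2 (2-(methoxycarbonyl)ethenyl in place of hydrogen on an oxygen on a saturated carbon). Among the compounds with values here, the one measured step is a step that the two limits leave unreadable from compound 1 to compound 2, so it offers no size to carry over. The expectation is therefore a tentative one, of somewhat stronger growth inhibition in this assay, and compound 4 may still stop at the limit. The expected step is an at least 2.5-fold lower number from compound 2 to compound 4 (0.39 log units; beyond the scatter). For compound 4 the estimated value is 40000 nM, with an expected range of 12000 nM to 100000 nM.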

Compound 4, concentration for 50% growth inhibition: 36000 nM
The estimate for compound 4 lay 1.1-fold (0.05 log units) above the measured number; low and high end bracket the measured number.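

In this assay, putting 2-(methoxycarbonyl)ethenyl in place of the hydrogen on this oxygen gives an at least 2.7-fold lower number from compound 2 to compound 4 (0.44 log units; beyond the scatter). From the compounds shown here alone, compound 2 gives > 100000 nM, which is a limit of the assay and not a number, so the true size of the step remains unknown. Compound 4 is the only compound shown with an exact value, which makes this oxygen the one place where a change can be seen to strengthen growth inhibition.

Going by these compounds, it remains open which part of the added group matters, the double bond or the methyl ester. A carboxylic acid in place of that ester, or the same group on the core of compound 1, could read differently.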